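Replacing the carboxy arm with an undecyl chain

The compounds below may be only part of what the source reports. "The series", "measured", "known", "first", "only" and "open" are said of these compounds alone.

Three compounds have been measured in an assay for inhibition of NAD-dependent protein deacylase sirtuin-6 (Homo sapiens), read by HPLC, with stated times of 15 min and 1 h, tested at 333 uM; on this read-out higher numbers stand for more inhibition at the one concentration tested (going by the name of the read-out) and lower numbers for less inhibition:

Compound 1 `O=C(CCCSC[C@H](NC(=O)OCc1ccccc1)C(=O)Nc1ccccc1)NCc1ccccc1` gives 30%
Compound 2 `CCCCCCCCCCNC(=O)CCCSC[C@H](NC(=O)OCc1ccccc1)C(=O)Nc1ccccc1` gives 28%
Compound 3 `O=C(O)CCNC(=O)CCCSC[C@H](NC(=O)OCc1ccccc1)C(=O)Nc1ccccc1` gives 43%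

Compound 3 stands highest of the three numbers in this assay; the step of a number 13 percentage points higher from compound 1 to compound 3 (beyond the scatter) and the step of a number 15 percentage points higher from compound 2 to compound 3 (beyond the scatter) are both beyond the scatter, so its number is the highest of the measured set, whereas compound 1 and compound 2 cannot be told apart, since a number 2 percentage points lower from compound 1 to compound 2 (within the scatter).

Compound 4 `CCCCCCCCCCCCCNC(=O)CCCSC[C@H](NC(=O)OCc1ccccc1)C(=O)Nc1ccccc1` differs from compound 3 in one place: undecyl in place of carboxy on a saturated chain carbon, two bonds along the chain from an amide-type nitrogen.

The step that bears on this change most directly is a number 15 percentage points higher from compound 2 to compound 3 (beyond the scatter), where a carboxy took the place of an octyl; compound 4 runs the other way, putting a long alkyl chain where the carboxy sat. The step of a number 2 percentage points lower from compound 1 to compound 2 (within the scatter) adds that a long alkyl chain and a phenyl gave numbers within the scatter of each other. A loss of the gain seen for compound 3 is therefore expected, and the step of a number 16 percentage points lower from compound 3 to compound 4 (beyond the scatter) is estimated to be of modest size, downward. Compound 4 is expected to give about 27% in this assay, in the range 15% to 40%.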

Compound 4, a percentage reported as inhibition, at one concentration (the size of the read-out at that concentration, not a potency): 31%
Compound 4: middle estimate off by 4 percentage points, on the low side; low and high end bracket the measured number.
By their numbers in this assay, from the lowest: compounds 2, 1 and 4 (each within the scatter of the next); then compound 3.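

In this assay the step of a number 12 percentage points lower from compound 3 to compound 4 (beyond the scatter) shows that an undecyl chain in place of carboxy does not hold the number seen for compound 3, so a long alkyl chain at this place does not match the carboxy-ended arm. The steps of a number 3 percentage points higher from compound 2 to compound 4 (within the scatter) and a number 1 percentage points higher from compound 1 to compound 4 (within the scatter) show that this compound cannot be told apart from either the shorter-chain or the phenyl compound, so neither step separates a longer alkyl chain from the groups it replaces. No measurement shown here explains why the carboxy-ended arm stands apart.

As far as these compounds go, it remains open whether an amine, a hydroxyl or a methyl ester in place of the carboxy would give a number like that of compound 3. A shorter chain carrying the carboxylic acid is also an open case.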